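The compounds below may be only part of what the source reports. "The series", "measured", "known", "first", "only" and "open" are said of these compounds alone.

Measured so far in a functional assay on HT-29 cells (Homo sapiens) for inhibition; a higher number here means a weaker inhibitor, a lower number a stronger inhibitor:
- compound 1 `Oc1ccc(/C=C/c2ccc3ccccc3c2)cc1` gives 4060 nM
- compound 2 `FC(F)(F)Oc1ccc(/C=C/c2ccc3ccccc3c2)cc1` gives > 5000 nM (a limit)
- compound 3 `FC(F)(F)c1ccc(/C=C\c2ccc3ccccc3c2)cc1` gives > 5000 nM (a limit)

For compound 2 the reading > 5000 nM is a limit of the assay and not a number. Compound 2 thus stands on the limit of > 5000 nM in this assay, at which 2 of the 3 values shown sit, and cannot be ranked exactly.

Compound 4 `CN(C)c1ccc(/C=C/c2ccc3ccccc3c2)cc1` has not yet been measured. The change is dimethylamino in place of trifluoromethoxy on an aromatic carbon and puts dimethylamino in place of trifluoromethoxy on an aromatic carbon, para to a large group. Among the measured compounds shown here, one measured step bears on this place: an at least 1.2-fold higher number from compound 1 to compound 2 (0.09 log units; that floor lies within the scatter) is the step that brings in the trifluoromethoxy, and it gives only a floor. For the measured compounds named here, no measured compound carries dimethylamino, so the evidence is thin. Going by the values given here, compound 1 with 4060 nM is the sole exact number in the set and gives the best guide to the level.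

A modest move towards a lower number is therefore expected in this assay, and it may not clear the scatter: the expected change is an at least 1.6-fold lower number from compound 2 to compound 4 (0.22 log units; that floor lies within the scatter) on this estimate. Compound 4 is estimated at 3000 nM with a range of 800 nM to 5000 nM and may yet report only a limit.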

Compound 4, half-maximal inhibitory concentration: 3660 nM
Estimate against measurement, compound 4: 1.2-fold (0.09 log units) below; the range from low to high includes it.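

In this assay, dimethylamino in place of hydroxy on the aromatic carbon, para to a large group, reads as a 1.1-fold lower number from compound 1 to compound 4 (0.05 log units; within the scatter), so compound 4 gives a second exact number on the shared core and this assay does not tell the two groups apart. Dimethylamino in place of trifluoromethoxy reads as an at least 1.3-fold lower number from compound 2 to compound 4 (0.13 log units; that floor lies within the scatter), which is only a floor, and the true size of this step stays open. Compound 2 holds a limit and not a number: the limit of > 5000 nM in this assay, at which 2 of the 4 values shown sit.

From the compounds shown here alone, whether any group at this place can move the number beyond the scatter remains open, for instance a carboxylic acid, a primary amine or a longer alkoxy chain. Compound 3 differs from the others in more than one place, and the double-bond geometry therefore stays unresolved as a separate change.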